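The source may report more compounds than this note shows. Statements on the series, on what has been measured and on what is new or still open speak of the compounds shown alone.

Compound 1, with the structure `Cc1ncsc1C(=O)NCCC1CCN(S(=O)(=O)NC(=O)NC[C@@H]2C[C@@H]3C=C[C@@H]2C3)CC1`, was tested in a functional assay on the whole organism (blood) with Rattus norvegicus as the target, with stated times of 24 h and 1 h, at a dose of 5 mg/kg by the intraperitoneal route (a lower number here means a weaker effect, a higher number a stronger effect of the compound at the dose given), where compound 1 gives 11%. A second compound, compound 2 with the structure `O=C(NC1CCCCC1)NS(=O)(=O)N1CCC(CCNC(=O)c2csnn2)CC1`, gives in this assay a value of 19%, and the two numbers lie within the usual scatter of each other, so neither can be placed above the other. Compound 3, with the structure `O=C(NC[C@@H]1C[C@@H]2C=C[C@@H]1C2)NS(=O)(=O)N1CCC(CCNC(=O)c2cc(Cl)cc3cccnc23)CC1`, has not yet been measured. It differs from compound 1 by 6-chloroquinolin-8-yl in place of 4-methyl-1,3-thiazol-5-yl on a carbonyl carbon. Among the measured compounds shown here, no step between measured compounds guides this change, so the expectation rests on the weak numbers seen so far; a modest rise, a number 9 percentage points higher from compound 1 to compound 3 (within the scatter), is expected. For compound 3 a value of 20% is estimated, between 5% and 45%.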

Compound 3, a percentage reported as activity, at one dose (the size of the read-out at that dose, not a potency): 35%
Compound 3: middle estimate off by 15 percentage points, on the low side; low and high end bracket the measured number.
By their numbers in this assay, from the lowest: compounds 1 and 2 (each within the scatter of the next); then compound 3.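

Replacing 4-methyl-1,3-thiazol-5-yl with 6-chloroquinolin-8-yl on this carbonyl carbon swaps one five-membered aromatic ring for a larger pair of six-membered rings, and in this assay the change gives a number 24 percentage points higher from compound 1 to compound 3 (beyond the scatter) at the dose tested. Among the compounds shown here, this is the first difference that exceeds the scatter, so this position can influence the read-out, although the finding rests on a single pair. Nothing measured here explains the step.

As far as these compounds go, it remains open whether the chlorine or the added ring matters more. The unsubstituted quinolin-8-yl group, or a methyl group in place of the chlorine, would help separate the two.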